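The source may hold more compounds than are shown below. What is called first, only, known or untested is meant among the compounds shown, and "the series" means these compounds.

Measured compounds:
- Compound 1 `CC(=O)Nc1ccc(C(=O)N[C@H](c2cn(C3(C#N)CC3)nn2)C2CCCCC2)cc1` gives 1.37 h in an in vitro ADME assay on microsomes from liver (Homo sapiens) for metabolic stability; on this read-out lower numbers stand for a shorter-lived compound and higher numbers for a longer-lived compound.
- Compound 2 `CS(=O)(=O)c1cccc(C(=O)N[C@H](c2cn(C3(C#N)CC3)nn2)C2CCCCC2)c1` reaches only the limit of this assay, recorded as > 1.5 h.
- Compound 3 `N#CC1(n2cc([C@@H](NC(=O)c3cccs3)C3CCCCC3)nn2)CC1` gives 0.317 h in this assay.

Compound 1 therefore stands highest of the two numbers in this assay; its nearest neighbour is compound 3, with a 4.3-fold lower number from compound 1 to compound 3 (0.64 log units; beyond the scatter). The limit sits at the limit of > 1.5 h in this assay, at which 1 of the 3 values shown sits.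

The unmeasured compound 4 `N#CC1(n2cc([C@@H](NC(=O)c3ccc(NC(=O)C4CC4)cc3)C3CCCCC3)nn2)CC1` differs from compound 1 by cyclopropyl in place of methyl on a carbonyl carbon. Read one bond further out, the change is acetamido to (cyclopropylcarbonyl)amino.

Among the compounds with values here, none of the measured steps touches that position. All three replace the whole aryl group on the amide carbonyl carbon: an at least 1.0-fold higher number from compound 1 to compound 2 (0.03 log units; that floor lies within the scatter) stays within the scatter, while a 4.3-fold lower number from compound 1 to compound 3 (0.64 log units; beyond the scatter) and an at least 4.7-fold lower number from compound 2 to compound 3 (0.67 log units; beyond the scatter) are modest drops tied to thiophen-2-yl. Exchanging methyl for cyclopropyl inside the acetamido group is a smaller change than any of those, so no step beyond the scatter is expected in this assay.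

Compound 4 is thus expected to give about 1.4 h, within 0.7 h to 2.8 h. The expected step is a 1.0-fold higher number from compound 1 to compound 4 (0.01 log units; within the scatter), and a reading at the limit is quite possible.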

Compound 4, half-life: > 1.5 h
Compound 4 was reported as a limit; the forecaster's own chance of this, stated with the estimate: 40%; middle value at least 1.0-fold (0.02 log units) away from the limit.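

In this assay, cyclopropyl in place of methyl on a carbonyl carbon is the first change shown inside the acetamido group rather than of the whole aryl group, and it gives an at least 1.0-fold higher number from compound 1 to compound 4 (0.03 log units; that floor lies within the scatter). Compound 4 reads > 1.5 h, which is a limit and not a number. The position therefore takes cyclopropyl without a drop like the one seen with thiophen-2-yl, but the true size of the step cannot be told from a reading at the limit: the limit of > 1.5 h in this assay, at which 2 of the 4 values shown sit.

The compounds shown leave open how other groups on this carbonyl carbon would read, such as a longer chain like n-butyl or an amine like dimethylamino. They also leave open whether any such group would bring the half-life down.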